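Working notes: from compound 2 to compound 4

This account rests on a few compounds, and the source may have more. Where it says the series, first, only, none or still open, it means among the compounds named here.

Values measured so far in a functional assay on MCF7 cells (Homo sapiens) for cytotoxicity, read by MTT assay, with a stated time of 72 h (a higher number here means a weaker inhibitor, a lower number a stronger inhibitor), for three compounds
compound 1 `CCC(C)=C1C(=O)N(c2ccc(Cl)cc2)N(c2ccc(Cl)cc2)C1=O` gives 41600 nM
compound 2 `O=C1C(=Cc2ccc(Cl)cc2)C(=O)N(c2ccc(Cl)cc2)N1c1ccc(Cl)cc1` gives 28500 nM
compound 3 `COc1cc(C=C2C(=O)N(c3ccc(Cl)cc3)N(c3ccc(Cl)cc3)C2=O)cc(OC)c1OC` gives 16200 nM

Compound 2 stands at 28500 nM as the second highest of the three numbers, within the scatter of both compound 1 and compound 3. The unmeasured compound 4 `COc1cccc(C=C2C(=O)N(c3ccc(Cl)cc3)N(c3ccc(Cl)cc3)C2=O)c1OC` departs from compound 2 by 2,3-dimethoxyphenyl in place of 4-chlorophenyl on a double-bonded chain carbon bound to a double-bonded ring carbon and thus has 2,3-dimethoxyphenyl in place of 4-chlorophenyl on a double-bonded chain carbon bound to a double-bonded ring carbon. For the measured compounds named here, no pair of measured compounds differs in one place only, so the series offers no direct precedent for the size of this change. The nearest guide is compound 3, which also carries methoxy groups in that place and gives 16200 nM in this assay within the scatter of compound 2. On that single comparison, the estimated step of a 1.4-fold lower number from compound 2 to compound 4 (0.15 log units; within the scatter) is expected to run towards a lower number and to stay within the scatter. For compound 4 the expected value is 20000 nM with an estimated range from 9000 nM to 42000 nM in this assay pending measurement.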

Compound 4, half-maximal inhibitory concentration: 11900 nM
Beside the measured number, compound 4's estimate is 1.7-fold (0.23 log units) above it, within the range that was stated.
By their numbers in this assay, from the lowest: compounds 4, 3, 2 and 1 (each within the scatter of the next, the first and the last beyond it).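

In this assay the exchange of 4-chlorophenyl for 2,3-dimethoxyphenyl on a double-bonded chain carbon bound to a double-bonded ring carbon gives the only single-place step shown, a 2.4-fold lower number from compound 2 to compound 4 (0.38 log units; beyond the scatter), so the group at this position can move the number beyond the scatter, though only modestly. Compound 3 at 16200 nM and compound 4 at 11900 nM lie within the scatter of each other, so this read-out does not separate these two methoxy-bearing groups. Nothing on hand accounts for the step, and no cause can be assigned to it.

The compounds shown do not settle whether the step follows from losing the 4-chlorophenyl group or from gaining the methoxy groups, nor whether an unsubstituted phenyl group or a lone methoxy group on the ring would give a similar number. Also open, on these data alone, is how the number would respond at this position to an aromatic ring carrying an amine or a carboxylic acid, and whether any such change would move it further than this step did.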